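The compounds below may be only part of what the source reports. "The series", "measured", "known", "first", "only" and "open" are said of these compounds alone.

Of the compounds shown here, three with a shared core have numbers so far in a functional assay, read by Griess assay, with a stated time of 2.5 h (a lower number here means a stronger inhibitor, a higher number a weaker inhibitor), and they sit close together. Compound 3 `COc1cc(OC)c(OC)cc1/C=C/C(=O)c1cc(O)ccc1O` gives 2.44 ug/mL while compound 2 `COc1cc(OC)c(OC)cc1/C=C/C(=O)c1cc(Cl)ccc1O` gives 2.32 ug/mL and compound 1 `COc1cc(OC)c(OC)cc1/C=C/C(=O)c1ccc(-c2c[nH]cn2)cc1` gives 1.97 ug/mL so compound 3 stands level with both, all three lying within the usual scatter of repeated measurements.

Compound 4 `COc1cc(OC)c(OC)cc1/C=C/C(=O)c1ccc(O)cc1` has not been measured yet. It differs from compound 3 in one place, on a carbonyl carbon, where 4-hydroxyphenyl stands in place of 2,5-dihydroxyphenyl (4-hydroxyphenyl in place of 2,5-dihydroxyphenyl on a carbonyl carbon).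

Within the data shown here, only one measured step bears directly on this change. It puts hydroxy in place of chloro on an aromatic carbon, within the group that changes here, and it amounts to a 1.1-fold higher number from compound 2 to compound 3 (0.02 log units; within the scatter) which stays within the scatter. Among the measured compounds shown here, no measured step removes a hydroxy outright, so this evidence is indirect. Compound 1, with a different group on the carbonyl carbon, gives 1.97 ug/mL and that too lies within the scatter of compound 3.

No step beyond the scatter is therefore expected in this assay and no direction can be called. The estimated change is a 1.0-fold lower number from compound 3 to compound 4 (0.01 log units; within the scatter) and it is expected to be lost in the scatter. Compound 4 is expected at 2.4 ug/mL (estimated range 1.2 ug/mL to 5 ug/mL).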

Compound 4, half-maximal inhibitory concentration: 2.5 ug/mL
Compound 4: middle estimate off by 1.0-fold (0.02 log units), on the low side; the range from low to high includes it.
By their numbers in this assay, from the lowest: compounds 1, 2, 3 and 4 (each within the scatter of the next).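

In this assay, among these compounds, this is the first measured step in which the ring on the carbonyl carbon goes from two hydroxy groups to one, with the remaining hydroxy in a different place, and it gives a 1.0-fold higher number from compound 3 to compound 4 (0.01 log units; within the scatter), so this larger change does not move the number beyond the scatter. The two other comparisons agree: 4-hydroxyphenyl in place of 5-chloro-2-hydroxyphenyl gives a 1.1-fold higher number from compound 2 to compound 4 (0.03 log units; within the scatter), and hydroxy in place of 1H-imidazol-4-yl on an aromatic carbon gives a 1.3-fold higher number from compound 1 to compound 4 (0.10 log units; within the scatter), so all four groups at this position sit within the scatter of one another. Nothing measured here explains why these different groups give such similar numbers.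

Still open, on these data alone, is whether a phenyl with no hydroxy at all, or one carrying an amine or a carboxylic acid, would move the number beyond the scatter at this position. As far as these compounds go, the methoxy groups of the shared core are the same in all four compounds, so the effect of replacing them with hydroxy or ethoxy groups also remains unknown.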